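Replacing 3,4-dichlorophenyl with 4-acetylphenyl on the shared core

The source may report more compounds than this note shows. Statements on the series, on what has been measured and on what is new or still open speak of the compounds shown alone.

In a physicochemical assay for lipophilicity, read by LC-MS, measured as octanol-water partition, with a stated time of 2 h, at pH 7.4, tested at 1 uM (a higher number here means a more lipophilic compound, a lower number a more polar compound), compound 1 (`OC[C@H]1O[C@H](Oc2ccc(-c3ccc(Cl)cc3)cc2Cl)[C@@H](O)[C@@H](O)[C@@H]1O`) reads 3.3, and compound 2 (`Cc1ccc(-c2ccc(O[C@H]3O[C@H](CO)[C@@H](O)[C@H](O)[C@@H]3O)c(Cl)c2)cc1`) reads 3.3. Compound 3 (`OC[C@H]1O[C@H](Oc2ccc(-c3ccc(Cl)c(Cl)c3)cc2Cl)[C@@H](O)[C@@H](O)[C@@H]1O`) offers no number to start from, its result being "not determined" (no result reported). Compound 4 (`CC(=O)c1ccc(-c2ccc(O[C@H]3O[C@H](CO)[C@@H](O)[C@H](O)[C@@H]3O)c(Cl)c2)cc1`) differs from it by 4-acetylphenyl in place of 3,4-dichlorophenyl on an aromatic carbon. Among the measured compounds shown here, the only measured step nearby is no change at the digits printed from compound 1 to compound 2 (within the scatter), a swap of methyl for chloro that stays within the scatter. For the measured compounds named here, no measured step brings in an acetyl group. With compound 3 unmeasured, the expectation is read from compound 1 at 3.3: a moderate step down in this assay, beyond the scatter. Compound 4 is estimated at 2.6, with an expected range of 2.1 to 3.1.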

Compound 4, distribution coefficient: 2.1
Compound 4: the middle estimate sits 0.50 log units above what was measured, within the range that was stated.
By their numbers in this assay, from the lowest: compound 4; then compounds 1 and 2 (each within the scatter of the next).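

In this assay the acetyl change gives a number 1.20 log units lower from compound 2 to compound 4 (beyond the scatter) and a number 1.20 log units lower from compound 1 to compound 4 (beyond the scatter) on the shared core. The position had shown no response when methyl stood in place of chloro, yet it does respond to acetyl, and the step is the same size from either starting group. Still open, going by these compounds, is where an amine, a carboxylic acid or a longer chain would fall at this place, and steps from compound 3 cannot be read. Nothing measured here accounts for the size of the step.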